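This account rests on a few compounds, and the source may have more. Where it says the series, first, only, none or still open, it means among the compounds named here.

Compound 1 `Nc1ncnc2c([C@@H]3O[C@H](CO)[C@@H](O)[C@H]3O)cn(-c3ccc(Cl)cc3)c12`: > 64000 nM (a limit)
Compound 2 `Nc1ncnc2c([C@@H]3O[C@H](CO)[C@@H](O)[C@H]3O)cn(-c3ccc(Cl)c(F)c3)c12`: > 64000 nM (a limit)

In an ADME assay on cells (Macrophage, Mus musculus) for cytotoxicity (a higher number here means that more compound is tolerated, a lower number that less compound is tolerated), compound 2 stands only at a limit, > 64000 nM. Compound 3 `Nc1ncnc2c([C@@H]3O[C@H](CO)[C@@H](O)[C@H]3O)cn(-c3ccc(Br)cc3)c12` differs from compound 2 by 4-bromophenyl in place of 4-chloro-3-fluorophenyl on an aromatic nitrogen, with 4-bromophenyl in place of 4-chloro-3-fluorophenyl on an aromatic nitrogen. For the measured compounds named here, the one measured step, a step that the two limits leave unreadable from compound 1 to compound 2, offers no size to carry over, and the measured compounds share (the limit of > 64000 nM in this assay, at which 2 of the 2 values shown sit). No step beyond the scatter is therefore expected in this assay, and no direction can be given. The expected step is a number no higher from compound 2 to compound 3 (the limit leaves the size open). Compound 3 is estimated at 64000 nM, with an expected range of 25000 nM to 100000 nM.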

Compound 3, half-maximal cytotoxic concentration: > 64000 nM
Compound 3 ended at the assay's limit (the forecaster's own chance of this, stated with the estimate: 85%); the middle value lies on the limit itself.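

In this assay no step can be read among compound 1, compound 2 and compound 3, since all three stand at a limit: the limit of > 64000 nM in this assay, at which 3 of the 3 values shown sit.

Going by these compounds, whether these compounds differ at all, and at what concentration any of them becomes cytotoxic, stays open.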